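Trifluoromethyl to Hydroxy on the Anilide of Compound 2

A few compounds are considered here, and "the series" means these few. Any claim that something is new, unique, unknown or untested is made for them only; others in the source may bear on it.

Compound 1 `O=C(Nc1ccccc1C(F)(F)F)C1CCc2ccccc2N1C(=O)c1ccccc1`: 6340 nM
Compound 2 `CCCCCCCCC(=O)N1c2ccccc2CCC1C(=O)Nc1ccccc1C(F)(F)F`: 4220 nM
Compound 3 `O=C(Nc1ccccc1C(F)(F)F)C1CCc2ccccc2N1C(=O)c1ccccc1Cl`: 2150 nM

In a functional assay on NCI-H23 cells (Homo sapiens) for cytotoxicity, read by sulforhodamine B assay, with a stated time of 72 h (a lower number here means a stronger inhibitor of growth, a higher number a weaker inhibitor of growth), compound 2 gives 4220 nM and sits in the middle of the three numbers. On one side the step is a 1.5-fold lower number from compound 1 to compound 2 (0.18 log units; within the scatter), and its gap to compound 3 is a 2.0-fold lower number from compound 2 to compound 3 (0.29 log units; within the scatter), so on these numbers compound 2 is not set apart from either neighbour. The step from compound 1 to compound 3 is a 2.9-fold lower number from compound 1 to compound 3 (0.47 log units; beyond the scatter).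

Compound 4 `CCCCCCCCC(=O)N1c2ccccc2CCC1C(=O)Nc1ccccc1O` has not yet been measured. It differs from compound 2 in one place: hydroxy in place of trifluoromethyl on an aromatic carbon. Among the compounds with values here, none of the measured steps touches this ring; all three vary the group on the carbonyl carbon of the shared core, and the anilide stays the same throughout. Within the data shown here, there is thus no measured step from which the size or direction of this change can be read, and the expectation rests on compound 2 alone. Compound 4 is therefore expected to give a number near that of compound 2, with a step of a 1.2-fold higher number from compound 2 to compound 4 (0.07 log units; within the scatter) that stays within the scatter, though the range must be wide. The estimate for compound 4 is 5000 nM, between 1500 nM and 17000 nM.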

Compound 4, concentration for 50% growth inhibition: 55800 nM
Compound 4: middle estimate off by 11-fold (1.05 log units), on the low side, outside the stated range (above it).
By their numbers in this assay, from the lowest: compounds 3, 2 and 1 (each within the scatter of the next, the first and the last beyond it); then compound 4.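

The anilide ring, held constant across compound 1, compound 2 and compound 3, proves to be a sensitive position in this assay: hydroxy in place of trifluoromethyl, on an aromatic carbon ortho to a large group, gives a 13-fold higher number from compound 2 to compound 4 (1.12 log units; beyond the scatter). This step is larger than the largest earlier one, a 2.9-fold lower number from compound 1 to compound 3 (0.47 log units; beyond the scatter), which came from a change on the other side of the shared core. Nothing at hand bears on why the number rises at this position.

Only trifluoromethyl and hydroxy are shown here, so a methoxy group, a fluorine atom or an amine would be needed to tell whether hydroxy raises the number or trifluoromethyl lowers it. On these data alone, it also remains open whether the change has a similar size with phenyl or 2-chlorophenyl in place of octyl on the carbonyl carbon.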